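Chloro to fluoro on the aryl ring of compound 3

The source may report more compounds than this note shows. Statements on the series, on what has been measured and on what is new or still open speak of the compounds shown alone.

Compound 3 `O[C@@H]1Cc2ccccc2N[C@H](c2ccc(Cl)cc2)C1` was tested in an ADME assay on Vero cells (Chlorocebus sabaeus) for cytotoxicity, read by MTT assay, with a stated time of 72 h; a lower number here means that less compound is tolerated, a higher number that more compound is tolerated. In this assay compound 3 returns only a limit, > 300000 nM. The parent compound 1 `O[C@@H]1Cc2ccccc2N[C@H](c2ccccc2)C1` likewise reaches only a limit, > 300000 nM. Within the data shown here, compound 2 `O[C@@H]1Cc2cc(OC(F)(F)F)ccc2N[C@H](c2ccccc2)C1` is the one member that gives a number, 124000 nM. Among the measured compounds shown here, the step of an at least 2.4-fold lower number from compound 1 to compound 2 (0.38 log units; beyond the scatter) is therefore the only measured step of readable size, while the step that the two limits leave unreadable from compound 1 to compound 3 cannot be sized, because both ends sit on the limit described by the limit of > 300000 nM in this assay, at which 2 of the 3 values shown sit.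

Compound 4 `O[C@@H]1Cc2ccccc2N[C@H](c2ccc(F)cc2)C1` differs from compound 3 by fluoro in place of chloro on an aromatic carbon. For the measured compounds named here, no measured step swaps one halogen for another, so the change has no direct precedent here. What the data do show is that chloro on that ring leaves compound 3 at the limit, and that the unmeasured compound 4 keeps the same core and the same single heavy atom on that ring. Compound 4 is therefore expected to stay near the limit as well, with the step of a number no higher from compound 3 to compound 4 (the limit leaves the size open) estimated to fall within the scatter, in no particular direction. For compound 4 the estimate in this assay is 300000 nM, with a range from 150000 nM to 600000 nM.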

Compound 4, half-maximal cytotoxic concentration: > 300000 nM
Compound 4 ended at the assay's limit (the forecaster's own chance of this, stated with the estimate: 75%); the middle value lies on the limit itself.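

In this assay compound 4 returns only a limit, > 300000 nM. No new step can be read from compound 4 to compound 1 or compound 3, because all three sit on the same limit: the limit of > 300000 nM in this assay, at which 3 of the 4 values shown sit. The compounds shown leave open how far compound 1, compound 3 and compound 4 differ from one another in this assay.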